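The compounds below may be only part of what the source reports. "The series", "measured", "known", "first", "only" and "open" are said of these compounds alone.

In a functional assay on KB cells (Homo sapiens) for antiproliferative activity, read by sulforhodamine B assay, with a stated time of 3 days (a higher number here means that more compound is needed for the effect, a lower number that less compound is needed), compound 1 `CCC1=C(O)c2c(oc(-c3ccc(F)cc3)cc2=O)C(CC)(CC)C1=O` gives 33 uM, compound 2 `CCC1=C(O)c2c(oc(-c3ccc(C)c(C)c3)cc2=O)C(CC)(CC)C1=O` gives 35.5 uM and compound 3 `CCC1=C(O)c2c(oc(-c3ccc(OC)c(C)c3)cc2=O)C(CC)(CC)C1=O` gives 28.5 uM, so compound 3 stands level with the other two within the scatter. Compound 4 `CCC1=C(O)c2c(oc(-c3cc(C)c(O)c(C)c3)cc2=O)C(CC)(CC)C1=O` differs from it in one group, on an aromatic carbon next to the ring oxygen: 4-hydroxy-3,5-dimethylphenyl in place of 4-methoxy-3-methylphenyl on an aromatic carbon. The closest evidence is a 1.2-fold lower number from compound 2 to compound 3 (0.10 log units; within the scatter), alongside a 1.2-fold lower number from compound 1 to compound 3 (0.06 log units; within the scatter) and a 1.1-fold higher number from compound 1 to compound 2 (0.03 log units; within the scatter), all within the scatter. Within the data shown here, no measured compound has a hydroxy group on this phenyl ring, so the evidence is indirect. The expected change is a 1.1-fold lower number from compound 3 to compound 4 (0.04 log units; within the scatter), with no shift beyond the scatter anticipated in this assay. Compound 4 is estimated at 26 uM, with an expected range of 11 uM to 55 uM.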

Compound 4, concentration for half-maximal effect: 18.3 uM
For compound 4 the middle estimate is 1.4-fold (0.15 log units) above the measured one, and the stated range covers the measured number.
By their numbers in this assay, from the lowest: compounds 4, 3, 1 and 2 (each within the scatter of the next).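

Among these compounds, compound 4 is the first compound here with a hydroxy group on this phenyl ring, and in this assay the change to 4-hydroxy-3,5-dimethylphenyl gives a small step (a 1.6-fold lower number from compound 3 to compound 4 (0.19 log units; within the scatter)). The steps from the other two compounds (a 1.9-fold lower number from compound 2 to compound 4 (0.29 log units; within the scatter); a 1.8-fold lower number from compound 1 to compound 4 (0.26 log units; within the scatter)) show that this position accepts a hydrogen-bond donor without a shift beyond the scatter. No measurement here bears on why these steps are so small. From the compounds shown here alone, it remains open whether an amine or a carboxylic acid on this phenyl ring, or a longer chain in place of its methyl groups, would move the number beyond the scatter.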